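From a Phenyl to a Methyl on Sulfur

The compounds below may be only part of what the source reports. "The series", "measured", "known", "first", "only" and "open" are said of these compounds alone.

Compound 1 `CC1(Sc2ccccc2)C(=O)N(c2ccccc2)c2ncccc21`: 0%
Compound 2 `COc1ccc(N2C(=O)C(C)(C)c3cccnc32)cc1`: 42%

In a functional assay on the whole organism (Pleural cavity) for inhibition, with Rattus norvegicus as the target, at a dose of 25 mg/kg (a higher number here means more inhibition at the dose given (going by the name of the read-out), a lower number less inhibition), compound 1 gives 0%, the lower of the two measured numbers, while compound 2 gives 42%, a reading higher by more than the usual scatter. Compound 3 `CSC1(C)C(=O)N(c2ccccc2)c2ncccc21` has not yet been measured. It differs from compound 1 in one place: methyl in place of phenyl on a sulfur. Within the data shown here, no measured pair shares this change, so the size of the step in this assay is uncertain; a modest rise is expected, perhaps not beyond the scatter. Compound 3 is expected to give 15%, with a range from 0% to 40%. The expected step is a number 15 percentage points higher from compound 1 to compound 3 (beyond the scatter).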

Compound 3, a percentage reported as inhibition, in the whole organism at one dose (the size of the read-out at that dose, not a potency): 53%
Estimate against measurement, compound 3: 38 percentage points below, outside the stated range (above it).
By their numbers in this assay, from the lowest: compound 1; then compound 2; then compound 3.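

In this assay, among these compounds, the change from phenylsulfanyl to methylsulfanyl gives a number 53 percentage points higher from compound 1 to compound 3 (beyond the scatter), the first step at this position that can be read from a pair differing in one place. It shows that the read-out at this dose depends strongly on the group carried by the sulfur. Nothing available explains the size of this step.

From the compounds shown here alone, it remains open whether a longer chain, such as ethyl or propyl, on the sulfur would keep this reading. Going by these compounds, the effect of an amine or a carboxylic acid at the end of such a chain also remains open.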